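Lengthening the ester chain in a piperazine-linked anilinoquinazoline series

The source may report more compounds than this note shows. Statements on the series, on what has been measured and on what is new or still open speak of the compounds shown alone.

Measured compounds:
Compound 1, `CCCCCCOC(=O)CCC(=O)N1CCN(CCCOc2cc3c(Nc4ccc(F)c(Cl)c4)ncnc3cc2OC)CC1`: 85.1%
Compound 2, `CCCCCCCCCOC(=O)CCC(=O)N1CCN(CCCOc2cc3c(Nc4ccc(F)c(Cl)c4)ncnc3cc2OC)CC1`: 79.7%
Compound 3, `CCCCCCCCCCCCCCOC(=O)CCC(=O)N1CCN(CCCOc2cc3c(Nc4ccc(F)c(Cl)c4)ncnc3cc2OC)CC1`: 92.3%

All three share one core and differ only in the length of the saturated chain on the ester. In a functional assay on A549 cells (Homo sapiens) for cytotoxicity, read by MTT assay, with a stated time of 24 h, tested at 20 uM (a lower number here means a stronger effect, a higher number a weaker effect of the compound at the concentration tested), compound 3 gives the highest of the three numbers; the gap to compound 1 is within the scatter, the gap to compound 2 is beyond it, and so compound 3 can only be called a weaker effector than compound 2, not than compound 1.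

Compound 4, `CCCCCCCCCCCCCCCCCOC(=O)CCC(=O)N1CCN(CCCOc2cc3c(Nc4ccc(F)c(Cl)c4)ncnc3cc2OC)CC1`, continues the same series with one change: propyl in place of hydrogen on a saturated chain carbon, ten or more bonds along the chain from an oxygen next to a carbonyl group. Within the data shown here, three measured steps bear on this. The step of a number 5.4 percentage points lower from compound 1 to compound 2 (within the scatter) and the step of a number 7.2 percentage points higher from compound 1 to compound 3 (within the scatter) stay within the scatter, while the step of a number 12.6 percentage points higher from compound 2 to compound 3 (beyond the scatter) is modest but beyond it. Taken together they give no consistent direction for added chain length, and the two steps within the scatter suggest that another extension will change little.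

The expected number for compound 4 is therefore close to that of compound 3, with an estimated step of a number 2.3 percentage points lower from compound 3 to compound 4 (within the scatter). Compound 4 is estimated at 90% in this assay, with a range from 78% to 100%.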

Compound 4, a percentage reported as activity, at one concentration (the size of the read-out at that concentration, not a potency): 97.2%
Compound 4: middle estimate off by 7.2 percentage points, on the low side; measured number inside the range.
By their numbers in this assay, from the lowest: compounds 2, 1, 3 and 4 (each within the scatter of the next, the first and the last beyond it).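

In this assay, among these compounds, the further propyl gives a number 4.9 percentage points higher from compound 3 to compound 4 (within the scatter), so this extension at the far end of the chain cannot be told from scatter, yet compound 4 is the first compound to stand clear of both shorter esters, with a number 17.5 percentage points higher from compound 2 to compound 4 (beyond the scatter) and a number 12.1 percentage points higher from compound 1 to compound 4 (beyond the scatter). Compound 3 could be separated only from compound 2, so the separation from compound 1 is new, and it appears only across the whole span of chain length, not in any single extension from compound 1 or from compound 3. The propyl extension also reads alike at the two chain lengths where it can be compared, which gives no sign that its effect depends on where along the chain it is added: the same change on two cores in this assay, a number 5.4 percentage points lower (within the scatter) from compound 1 to compound 2 and a number 4.9 percentage points higher (within the scatter) from compound 3 to compound 4, 10.3 percentage points apart, within the scatter of two such steps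

With only saturated chains on the ester, the compounds shown leave open whether a hydroxyl group or an amine at the far end of the chain, or a carboxylic acid in place of the ester, would change the number in this assay. They also leave open whether a chain longer than that of compound 4 would move the number any further.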